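A few compounds are considered here, and "the series" means these few. Any claim that something is new, unique, unknown or untested is made for them only; others in the source may bear on it.

Working notes on the series. Compound 3 `O=C(O)CCc1ccc(C#Cc2ccnc(-c3ccccc3)c2)cc1` gives 186 nM in an in vitro functional assay on 1321-N1 cells for agonist activity at Free fatty acid receptor 1 (Homo sapiens), read by fluorescence, spectrophotometry and calcium flux; on this read-out lower numbers stand for an effect already at smaller amounts and higher numbers for an effect only at larger amounts of compound; of the three numbers in hand it is the second highest. Compound 2 `O=C(O)CCc1ccc(C#Cc2ccnc3cc(Cl)ccc23)cc1` gives 79.4 nM, a lower number than compound 3 and beyond the scatter. Compound 1 `Cc1cc(C#Cc2ccc(CCC(=O)O)cc2)nc(Cl)n1` gives 2750 nM, far above compound 3 and also beyond the scatter. Compound 4 `O=C(O)CCc1ccc(C#Cc2ccnc(Cl)c2)cc1` is not yet measured. It differs from compound 3 by chloro in place of phenyl on an aromatic carbon. Going by the values given here, no step between measured compounds matches this change, so the direction rests on the three numbers alone. The phenyl compound 3 and the chloro compounds 1 and 2 do not speak with one voice, since compound 2 is low and compound 1 high. The expectation for compound 4 is a modest rise, a 3.2-fold higher number from compound 3 to compound 4 (0.51 log units; beyond the scatter), beyond the scatter. Compound 4 is estimated at 600 nM, between 200 nM and 2000 nM.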

Compound 4, half-maximal effective concentration: 295 nM
Compound 4: the middle estimate sits 2.0-fold (0.31 log units) above what was measured; the range from low to high includes it.
By their numbers in this assay, from the lowest: compound 2; then compounds 3 and 4 (each within the scatter of the next); then compound 1.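

Chloro in place of phenyl on this aromatic carbon, next to the ring nitrogen, gives a 1.6-fold higher number from compound 3 to compound 4 (0.20 log units; within the scatter) in this assay. This first direct step at this place shows that the read-out does not separate a single chlorine from a whole phenyl ring, so both groups are tolerated here to a similar degree. No measurement at hand explains this result.

From the compounds shown here alone, whether an amine, a methoxy group or plain hydrogen at this place would stay in the same range remains open. So does the effect of a substituted phenyl there.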